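The compounds below may be only part of what the source reports. "The series", "measured", "known", "first", "only" and "open" are said of these compounds alone.

Notes on the series. Compound 1 `COc1ccc(C2CC2C(=O)NNc2nncc3ccccc23)cc1` gives 96000 nM in a functional assay on A549 cells (Homo sapiens) for inhibition, read by MTT assay, with a stated time of 72 h; a higher number here means a weaker inhibitor, a lower number a stronger inhibitor. Compound 2 `CCOc1ccc(C2CC2C(=O)NNc2nncc3ccccc23)cc1` is reported in this assay only as a limit, > 100000 nM. The step of an at least 1.0-fold higher number from compound 1 to compound 2 (0.01 log units; that floor lies within the scatter) is accordingly bounded by the limit of > 100000 nM in this assay, at which 1 of the 2 values shown sits, and carries no measured direction of its own. Compound 3 `CC(C)=CCOc1ccc(C2CC2C(=O)NNc2nncc3ccccc23)cc1` differs from compound 2 by 2-methylprop-1-en-1-yl in place of methyl on a saturated chain carbon bound to an oxygen on an aromatic ring. Within the data shown here, the one step that bears on this change, from compound 1 to compound 2, sits at the scatter floor and against the limit, so it offers no size and no direction to carry forward. Compound 2 stands at the limit of this assay. On that footing the step of a number no higher from compound 2 to compound 3 (the limit leaves the size open) is an expectation of no change beyond the scatter. Compound 3 is therefore estimated at 100000 nM in this assay, with a range from 30000 nM to 300000 nM, and a substantial chance that the measurement again returns only a limit.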

Compound 3, half-maximal inhibitory concentration: 82000 nM
Compound 3: middle estimate off by 1.2-fold (0.09 log units), on the high side; measured number inside the range.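

With the chain of compound 3, a measured value returns at this position in this assay, whereas compound 2 gave only a limit. The step reads an at least 1.2-fold lower number from compound 2 to compound 3 (0.08 log units; that floor lies within the scatter), which gives a floor and no measured size, and it is bounded by a limit: the limit of > 100000 nM in this assay, at which 1 of the 3 values shown sits. The comparison with both ends measured reads a 1.2-fold lower number from compound 1 to compound 3 (0.07 log units; within the scatter), so this change on the ether chain leaves the number within the scatter, even with this much larger group.

From the compounds shown here alone, whether an amine or a carboxylic acid at the end of this chain would move the number beyond the scatter remains open. Also open, going by these compounds, is whether a change elsewhere on the shared core would do so, since all three compounds differ only in this ether chain.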